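Phenyl for 1,3-thiazol-2-yl: cytotoxicity notes

The source may hold more compounds than are shown below. What is called first, only, known or untested is meant among the compounds shown, and "the series" means these compounds.

Measured so far in an ADME assay on MT4 cells (Homo sapiens) for cytotoxicity; on this read-out higher numbers stand for lower toxicity in this test and lower numbers for higher toxicity in this test (both values are limits)
- compound 1 `COC(=O)N[C@H](C(=O)NN(CCC[C@@](O)(Cc1ccccc1)C(=O)N[C@H]1c2ccccc2C[C@H]1O)Cc1ccccc1)C(C)(C)C` gives > 10000 nM (limit)
- compound 2 `COC(=O)N[C@H](C(=O)NN(CCC[C@@](O)(Cc1ccccc1)C(=O)N[C@H]1c2ccccc2C[C@H]1O)Cc1ccc(-c2nccs2)cc1)C(C)(C)C` gives > 10000 nM (limit)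

Compound 2 gives > 10000 nM as a limit, not a number. Compound 1 shares that position (the limit of > 10000 nM in this assay, at which 2 of the 2 values shown sit). Compound 3 `COC(=O)N[C@H](C(=O)NN(CCC[C@@](O)(Cc1ccccc1)C(=O)N[C@H]1c2ccccc2C[C@H]1O)Cc1ccc(-c2ccccc2)cc1)C(C)(C)C` differs from compound 2 by phenyl in place of 1,3-thiazol-2-yl on an aromatic carbon. Only a step that the two limits leave unreadable from compound 1 to compound 2 bears on this and it sets no size, so no step beyond the scatter is expected in this assay from this change. The expected change is a step that the limit leaves unreadable from compound 2 to compound 3 in this estimate. Compound 3 is expected at 12000 nM (estimated range 5000 nM to 30000 nM), quite possibly reported only as a limit.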

Compound 3, half-maximal cytotoxic concentration: 7500 nM
Compound 3: middle estimate off by 1.6-fold (0.20 log units), on the high side; the measured number falls inside the stated range.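

In this assay compound 3 gives 7500 nM, the only actual number among the compounds shown. The readable steps are an at least 1.3-fold lower number from compound 2 to compound 3 (0.12 log units; that floor lies within the scatter) and an at least 1.3-fold lower number from compound 1 to compound 3 (0.12 log units; that floor lies within the scatter), so neither phenyl in place of 1,3-thiazol-2-yl nor phenyl in place of hydrogen is shown to move the read-out beyond the scatter. The step from compound 1 to compound 2 cannot be read: the limit of > 10000 nM in this assay, at which 2 of the 3 values shown sit.

Still open, from the compounds shown here alone, is whether a carboxylic acid or an amine at this place would give a number, and how that number would compare with compound 3.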